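Propyl Ester on the Thiophene Core: An Expected Binding Read-out

The compounds below may be only part of what the source reports. "The series", "measured", "known", "first", "only" and "open" are said of these compounds alone.

Of the compounds shown here, three built on one shared core have been measured, and they differ at two places. Compound 1 `COC(=O)C1=C(C)NC(=S)NC1c1ccoc1` carries a methoxycarbonyl group and a furan-3-yl ring; in an assay on membranes from CHO cells for displacement of a labelled ligand from adenosine receptor A1 (Homo sapiens), read by scintillation counting, with a stated time of 60 min, tested at 1 uM (on this read-out higher numbers stand for more inhibition at the one concentration tested (going by the name of the read-out) and lower numbers for less inhibition), compound 1 gives 25%. Compound 2 `CCCOC(=O)C1=C(C)NC(=S)NC1c1ccoc1` differs from compound 1 by ethyl in place of hydrogen on a saturated chain carbon bound to an oxygen next to a carbonyl group, and in this assay compound 2 gives 4%. That change made a modest step, a number 21 percentage points lower from compound 1 to compound 2 (beyond the scatter). Compound 3 `COC(=O)C1=C(C)NC(=S)NC1c1ccsc1` differs from compound 1 in the ring on the saturated ring carbon, (thiophen-3-yl in place of furan-3-yl on a saturated ring carbon), and in this assay compound 3 gives 3%. The step here was a number 22 percentage points lower from compound 1 to compound 3 (beyond the scatter). Compound 2 and compound 3 lie within the usual scatter of each other, so no order between them can be claimed.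

Compound 4 `CCCOC(=O)C1=C(C)NC(=S)NC1c1ccsc1` has not yet been measured. It differs from compound 3 by ethyl in place of hydrogen on a saturated chain carbon bound to an oxygen next to a carbonyl group, the same change, at the same place, that turned compound 1 into compound 2; among these compounds this change occurs twice. The earlier step was a number 21 percentage points lower from compound 1 to compound 2 (beyond the scatter). A lowering of that size cannot repeat in full, because compound 3 already gives 3%, which sits near the bottom of a percentage scale of inhibition. The expected step is therefore small, a number 1 percentage points lower from compound 3 to compound 4 (within the scatter). Compound 4 is expected to give 2%. The likely range for compound 4 runs from an estimated -8% to an estimated 12%.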

Compound 4, a percentage reported as inhibition, at one concentration (the size of the read-out at that concentration, not a potency): 5%
For compound 4 the middle estimate is 3 percentage points below the measured one; the range from low to high includes it.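

In this assay, the change from methoxycarbonyl to propoxycarbonyl gives a number 2 percentage points higher from compound 3 to compound 4 (within the scatter), so the drop seen on the furan-3-yl compounds does not carry over to the thiophen-3-yl compounds: the same change on two cores in this assay, a number 21 percentage points lower (beyond the scatter) from compound 1 to compound 2 and a number 2 percentage points higher (within the scatter) from compound 3 to compound 4, 23 percentage points apart, beyond the scatter of two such steps The ring change tells the same story, since thiophen-3-yl in place of furan-3-yl gives a number 1 percentage points higher from compound 2 to compound 4 (within the scatter), and its earlier drop does not reappear on the propoxycarbonyl compounds: the same change on two cores in this assay, a number 22 percentage points lower (beyond the scatter) from compound 1 to compound 3 and a number 1 percentage points higher (within the scatter) from compound 2 to compound 4, 23 percentage points apart, beyond the scatter of two such steps This shows that, among these four compounds, neither step can be carried from one core to another at its earlier size, but it does not show why, for compound 2, compound 3 and compound 4 all lie near the bottom of the scale, where a further drop has little room to appear, and only compound 1 stands apart from them.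

The compounds shown leave open how a longer chain or a branched chain in the ester, or a carboxylic acid or an amide in its place, would read in this assay. They also leave open whether a phenyl ring on the saturated ring carbon would give a number clearly above that of compound 1, which would offer more room for these two changes to be compared.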